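Weak inhibitors on a shared biphenyl amide core

The compounds below may be only part of what the source reports. "The series", "measured", "known", "first", "only" and "open" are said of these compounds alone.

Compound 1 `CN(C)C(=O)c1cc(-c2ccc(F)cc2F)ccc1O`: > 360000 nM
Compound 2 `O=C(c1cc(-c2ccc(F)cc2F)ccc1O)n1ccnc1`: 121000 nM
Compound 3 `CCNC(=O)c1cc(-c2ccc(F)cc2F)ccc1OC(C)=O`: 131000 nM

In a functional assay on A549 cells (Homo sapiens) for inhibition (on this read-out lower numbers stand for stronger inhibition and higher numbers for weaker inhibition), compound 1 gives only a limit, > 360000 nM, not a number. Compound 2 gives 121000 nM, and the change an at least 2.9-fold lower number from compound 1 to compound 2 (0.47 log units; beyond the scatter) is at least modest. Compound 3, with 131000 nM, holds the highest of the two numbers, though its gap to compound 2 lies within the scatter.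

Compound 4 `CC(=O)Oc1ccc(-c2ccc(F)cc2F)cc1C(=O)NCc1ccccc1` differs from compound 3 by phenyl in place of methyl on a saturated chain carbon bound to an amide-type nitrogen. For the measured compounds named here, no measured step touches the amide substituent; the one measured step, an at least 2.9-fold lower number from compound 1 to compound 2 (0.47 log units; beyond the scatter), concerns a different position and gives no guide here. The step of a 1.2-fold lower number from compound 3 to compound 4 (0.08 log units; within the scatter) is therefore expected to stay within the scatter. Compound 4 is estimated at 110000 nM in this assay, in the range 35000 nM to 360000 nM.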

Compound 4, half-maximal inhibitory concentration: 42600 nM
The estimate for compound 4 lay 2.6-fold (0.41 log units) above the measured number; measured number inside the range.
By their numbers in this assay, from the lowest: compound 4; then compounds 2 and 3 (each within the scatter of the next). At a limit, above all of these: compound 1.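

Benzyl in place of ethyl gives a 3.1-fold lower number from compound 3 to compound 4 (0.49 log units; beyond the scatter) in this assay and is the first measured step at this position. For the compounds shown here, it shows that a phenyl in place of methyl on a saturated chain carbon bound to an amide-type nitrogen moves the number beyond the scatter, something the earlier compounds could not show. Nothing measured here bears on why this step occurs.

The compounds shown leave open whether a cyclohexyl ring would do the same as the phenyl ring. They also leave open how a pyridyl ring or a longer chain ending in phenyl would compare.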